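This account rests on a few compounds, and the source may have more. Where it says the series, first, only, none or still open, it means among the compounds named here.

In a functional assay on MCF7 cells (Homo sapiens) for cytotoxicity, read by MTT assay, with a stated time of 72 h (on this read-out lower numbers stand for stronger inhibition and higher numbers for weaker inhibition), compound 1 (`CCC(C)=C1C(=O)N(c2ccc(Cl)cc2)N(c2ccc(Cl)cc2)C1=O`) gives 41600 nM and compound 2 (`O=C1C(=Cc2ccc(Br)cc2)C(=O)N(c2ccc(Cl)cc2)N1c1ccc(Cl)cc1`) gives 30400 nM as its reading. These two numbers lie within the usual scatter of each other, so compound 2 stands level with compound 1. Compound 3 (`COc1ccc(C=C2C(=O)N(c3ccc(Cl)cc3)N(c3ccc(Cl)cc3)C2=O)cc1OC`) carries 3,4-dimethoxyphenyl in place of 4-bromophenyl on a double-bonded chain carbon bound to a double-bonded ring carbon. Going by the values given here, no measured pair shows what such a swap does, so the expected step (a 1.1-fold lower number from compound 2 to compound 3 (0.04 log units; within the scatter)) is none beyond the scatter, with no direction foreseen. The estimated value for compound 3 is 28000 nM with an expected range from 12000 nM to 60000 nM until the measurement is known.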

Compound 3, half-maximal inhibitory concentration: > 128000 nM
Compound 3: a limit, no number (the forecaster's own chance of this, stated with the estimate: 8%); middle value at least 4.5-fold (0.66 log units) away from the limit.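

In this assay, 3,4-dimethoxyphenyl in place of 4-bromophenyl on a double-bonded chain carbon bound to a double-bonded ring carbon brings an at least 4.2-fold higher number from compound 2 to compound 3 (0.62 log units; beyond the scatter), so the group held at this place can change the reading, which the level values of compound 1 and compound 2 could not show. The reading of compound 3 is a limit, not a number: the limit of > 128000 nM in this assay, at which 1 of the 3 values shown sits.

As far as these compounds go, whether the weakening goes with the bromine leaving or the methoxy groups entering stays open. So does how a phenyl ring bearing an amine or a carboxylic acid would read at this place.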